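Swapping 2-Hydroxyphenyl for 4-Methylphenyl on a Shared Core

The compounds below may be only part of what the source reports. "The series", "measured", "known", "first", "only" and "open" are said of these compounds alone.

Of the compounds shown here, two sharing one core have been measured in a functional assay on HepG2 cells (Homo sapiens) for antiproliferative activity, read by MTT assay, with a stated time of 48 h; a lower number here means a stronger inhibitor, a higher number a weaker inhibitor. Compound 1 `CC(=O)N1N=C(c2ccc3ccccc3c2)OC1c1ccccc1F` gives 3.36 ug/mL, and compound 2 `CC(=O)N1N=C(c2ccc3ccccc3c2)OC1c1ccccc1O` gives 1.84 ug/mL. These two values lie within the scatter of each other, so compound 2 cannot be ranked against compound 1.

Compound 3 `CC(=O)N1N=C(c2ccc3ccccc3c2)OC1c1ccc(C)cc1` has not yet been measured. It keeps the core of compound 2 but carries 4-methylphenyl in place of 2-hydroxyphenyl on a saturated ring carbon. Within the data shown here, the new group has no hydrogen-bond donor or acceptor, and no measured compound carries it.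

Among the measured compounds shown here, only one measured step bears on this change: a 1.8-fold lower number from compound 1 to compound 2 (0.26 log units; within the scatter), with hydroxy in place of fluoro on an aromatic carbon. That step stayed within the scatter, but it is a thin guide, since it does not test a methyl group. No shift beyond the scatter is therefore expected in this assay. The expected change is a 1.4-fold higher number from compound 2 to compound 3 (0.13 log units; within the scatter), an estimate that remains within the scatter. For compound 3 the estimated value is 2.5 ug/mL, with an expected range from 1.1 ug/mL to 6 ug/mL.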

Compound 3, half-maximal inhibitory concentration: 2.26 ug/mL
Compound 3: the middle estimate sits 1.1-fold (0.04 log units) above what was measured, within the range that was stated.
By their numbers in this assay, from the lowest: compounds 2, 3 and 1 (each within the scatter of the next).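

In this assay, the saturated ring carbon that bears the aryl group accepted a swap of a whole group, not only of one substituent: the change to 4-methylphenyl gave a 1.2-fold higher number from compound 2 to compound 3 (0.09 log units; within the scatter), and the comparison with the 2-fluorophenyl compound gave a 1.5-fold lower number from compound 1 to compound 3 (0.17 log units; within the scatter). The earlier pair had shown only that fluoro and hydroxy on the same phenyl carbon could not be told apart, whereas this result adds that 4-methylphenyl, with 0 hydrogen-bond donors and 0 hydrogen-bond acceptors, also cannot be separated from 2-hydroxyphenyl, with 1 of each, so these three compounds give no sign that the hydroxy group is needed for this read-out. Nothing available explains why these groups fall so close together, and the data point to no cause.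

What the compounds shown leave open is whether any group on this ring carbon can move the number beyond the scatter, since no step among them does so. An amine or a carboxylic acid on the phenyl ring, or a longer chain such as butyl in the 4-position of that ring, would test this in a way that the fluoro, hydroxy and methyl groups cannot.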